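The source may report more compounds than this note shows. Statements on the series, on what has been measured and on what is new or still open speak of the compounds shown alone.

Three analogues sharing one core have been measured in a physicochemical assay for solubility, read by HPLC, in phosphate buffer, measured as kinetic solubility, with a stated time of 24 h, at 20 degrees C, at pH 7.4, tested at 100 uM; a higher number here means a more soluble compound, a lower number a less soluble compound. Compound 1, `CC(C)n1nc(-c2ccc3oc(N)nc3c2)c2c(CO)nc(N)nc21`, gives 82000 nM. Compound 2, `COc1nc(N)nc2c1c(-c1ccc3oc(N)nc3c1)nn2C(C)C`, gives a value that is only a limit of the assay, < 1000 nM. Compound 3, `CC(C)n1nc(-c2ccc3oc(N)nc3c2)c2c(Cl)nc(N)nc21`, gives 2000 nM, the lowest of the two numbers reported, with compound 1 as its nearest neighbour. The steps away from compound 1 are large: an at least 82-fold lower number from compound 1 to compound 2 (1.91 log units; beyond the scatter) and a 41-fold lower number from compound 1 to compound 3 (1.61 log units; beyond the scatter). Between compound 2 and compound 3 the step is an at least 2.0-fold higher number from compound 2 to compound 3 (0.30 log units; that floor lies within the scatter), one of the three values sitting at the limit of < 1000 nM in this assay, at which 1 of the 3 values shown sits.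

Compound 4, `CC(C)n1nc(-c2ccc3oc(N)nc3c2)c2c(Br)nc(N)nc21`, has not been measured in this assay. It differs from compound 3 by bromo in place of chloro on an aromatic carbon. Among the measured compounds shown here, no measured step swaps one halogen for another; the only changes recorded replace hydroxymethyl, and both of those were large. With nothing directly comparable, the exchange of chloro for bromo is expected to give a step of a 1.3-fold lower number from compound 3 to compound 4 (0.12 log units; within the scatter), that is, no change beyond the scatter. Compound 4 is therefore estimated at 1500 nM, within a range of 500 nM to 5000 nM.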

Compound 4, solubility: 4000 nM
The estimate for compound 4 lay 2.7-fold (0.43 log units) below the measured number; the range from low to high includes it.
By their numbers in this assay, from the lowest: compounds 3 and 4 (each within the scatter of the next); then compound 1. At a limit, below all of these: compound 2.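

In this assay, among the compounds shown here, the first exchange of one halogen for another at this position, on an aromatic carbon next to the ring nitrogen, is a 2.0-fold higher number from compound 3 to compound 4 (0.30 log units; within the scatter), so bromo and chloro cannot be told apart here. Bromo also leaves a large distance from hydroxymethyl, with a 21-fold lower number from compound 1 to compound 4 (1.31 log units; beyond the scatter), so that distance now holds for both halogens. The step to bromo from methoxy, an at least 4.0-fold higher number from compound 2 to compound 4 (0.60 log units; beyond the scatter), gives only a floor, yet unlike the floor for chloro it lies beyond the scatter, and compound 2 holds the only value that is a limit: the limit of < 1000 nM in this assay, at which 1 of the 4 values shown sits.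

From the compounds shown here alone, what an aminomethyl group, a carboxylic acid or a longer hydroxyethyl chain would give at this position stays open. Going by these compounds, it also stays open how far the true value of compound 2 lies from its limit.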